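The source may report more compounds than this note shows. Statements on the series, on what has been measured and on what is new or still open speak of the compounds shown alone.

Among the measured compounds shown here, compound 2 `COC(=O)C1=C(C)N=C(C)/C(=C(\O)OC)C1c1ccc(Cl)cc1Cl` carries the higher of the two numbers so far in a functional assay (muscle tissue) with Cavia porcellus as the target; on this read-out lower numbers stand for an effect already at smaller amounts and higher numbers for an effect only at larger amounts of compound: compound 2 gives 640 nM, while compound 1 `COC(=O)C1=C(C)N=C(C)/C(=C(\O)OC)C1c1cc(Cl)cc(Cl)c1` gives 93.3 nM. For the measured compounds named here, the one measured step, a 6.9-fold higher number from compound 1 to compound 2 (0.84 log units; beyond the scatter), moved only the arrangement of two chlorines on the aryl group. Compound 3 `COC(=O)C1=C(C)N=C(C)/C(=C(\O)OC)C1c1cccc(C#N)c1` is the next member; it differs from compound 2 as follows: 3-cyanophenyl in place of 2,4-dichlorophenyl on a saturated ring carbon. Going by the values given here, no measured step covers a nitrile on this aryl group, so the measured step bears on it only in showing that the substitution pattern of the aryl group is worth a step beyond the scatter, and that the 2,4-dichlorophenyl of compound 2 sits at the weaker end. A lower number is therefore expected for compound 3, and the step of a 3.6-fold lower number from compound 2 to compound 3 (0.55 log units; beyond the scatter) is an estimate, with a wide range. Compound 3 is estimated at 180 nM, between 40 nM and 800 nM.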

Compound 3, half-maximal effective concentration: 34.7 nM
Estimate against measurement, compound 3: 5.2-fold (0.71 log units) above, outside the stated range (below it).
By their numbers in this assay, from the lowest: compound 3; then compound 1; then compound 2.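

In this assay, the 3-cyanophenyl group on the saturated ring carbon gives a large change (an 18-fold lower number from compound 2 to compound 3 (1.27 log units; beyond the scatter)), so this position responds to more than the arrangement of two chlorines. The nitrile-bearing aryl group also improves on the better dichlorophenyl compound (a 2.7-fold lower number from compound 1 to compound 3 (0.43 log units; beyond the scatter)), which shows that neither chlorine pattern is needed for a low number here; compound 3 now has the lowest number of the three, with both of its steps beyond the scatter. Nothing available accounts for the size of either step.

Only one placement of the nitrile is shown, so its dependence on where it sits on the aryl group remains open. Also open, going by these compounds, is how an amine, a carboxylic acid or a single chlorine on the aryl group would compare at this position.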